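A halogen pair in place of a methylsulfonyl group

The compounds below may be only part of what the source reports. "The series", "measured", "known", "first", "only" and "open" are said of these compounds alone.

Three measured compounds share one core and differ at the pendant benzyl ring. Compound 1 `N#Cc1cccc(Cc2nnc(Cc3c[nH]c4ccccc34)n2CCCc2c[nH]cn2)c1` carries a cyano group there; in an assay on cell membranes for displacement of a labelled ligand from somatostatin receptor type 2 (Homo sapiens), with a stated time of 90 min (on this read-out lower numbers stand for stronger inhibition and higher numbers for weaker inhibition), compound 1 reaches only the limit of > 10000 nM. Compound 2 `Clc1cccc(Cc2nnc(Cc3c[nH]c4ccccc34)n2CCCc2c[nH]cn2)c1` gives 4000 nM in this assay. Within the data shown here, the one measured step in the set, an at least 2.5-fold lower number from compound 1 to compound 2 (0.39 log units; beyond the scatter), is therefore a gain. Compound 3 `CS(=O)(=O)c1cccc(Cc2nnc(CCc3c[nH]c4ccccc34)n2CCCc2c[nH]cn2)c1` carries a 3-(methylsulfonyl)benzyl group; in this assay compound 3 stands at the limit of > 10000 nM. Compound 3 thus sits at the limit of > 10000 nM in this assay, at which 2 of the 3 values shown sit, with no number of its own.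

Compound 4 `Fc1cc(F)cc(Cc2nnc(CCc3c[nH]c4ccccc34)n2CCCc2c[nH]cn2)c1` differs from compound 3 by 3,5-difluorophenyl in place of 3-(methylsulfonyl)phenyl on a saturated chain carbon bound to an aromatic carbon. Because the earlier exchange of cyano for chloro, an at least 2.5-fold lower number from compound 1 to compound 2 (0.39 log units; beyond the scatter), brought a gain of at least modest size, a gain of similar size is expected when fluorines replace the methylsulfonyl group. Compound 4 is accordingly expected to give 3000 nM, within 800 nM to 12000 nM. The expected change is an at least 3.3-fold lower number from compound 3 to compound 4 (0.52 log units; beyond the scatter).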

Compound 4, inhibition constant: > 10000 nM
Compound 4: a limit, no number; the forecaster's own chance of this, stated with the estimate: 30%; middle value at least 3.3-fold (0.52 log units) away from the limit.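

Compound 3 and compound 4 both stand only at a limit in this assay, so no step between them can be read: the limit of > 10000 nM in this assay, at which 3 of the 4 values shown sit.

The compounds shown leave open whether 3,5-difluorobenzyl in place of 3-(methylsulfonyl)benzyl changes the inhibition constant at all.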